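From 3,4-Difluorobenzyl to 2,3-Difluorobenzyl on Compound 1

This account rests on a few compounds, and the source may have more. Where it says the series, first, only, none or still open, it means among the compounds named here.

Measured in a functional assay on A-375 cells (Homo sapiens) for activation, with a stated time of 3 days; on this read-out lower numbers stand for an effect already at smaller amounts and higher numbers for an effect only at larger amounts of compound:
- Compound 1 `O=C(Nc1ccc(-c2cscn2)cc1)C1CCCN(Cc2ccc(F)c(F)c2)C1`: 1240 nM
- Compound 2 `O=C(Nc1ccc(-c2cscn2)cc1)C1CCN(Cc2ccc(F)c(F)c2)C1`: 8000 nM
- Compound 3 `O=C(Nc1ccc(-c2cscn2)cc1)C1CN(Cc2ccc(F)c(F)c2)C1`: > 20000 nM

Compound 1 at 1240 nM holds the lower of the two numeric values, and compound 2 at 8000 nM lies beyond the usual scatter from it. The entry for compound 3 is a limit of the assay and not a number.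

Compound 4 `O=C(Nc1ccc(-c2cscn2)cc1)C1CCCN(Cc2cccc(F)c2F)C1` has not yet been measured. It keeps the core of compound 1 and differs only on the benzyl group, with 2,3-difluorophenyl in place of 3,4-difluorophenyl on a saturated chain carbon bound to an amine nitrogen in a ring. For the measured compounds named here, no measured pair shows a change of this kind, so the expectation rests on compound 1 at 1240 nM. In this assay, a small rise in the number is expected, close to the scatter. The expected size of this change is a 1.5-fold higher number from compound 1 to compound 4 (0.16 log units; within the scatter). Compound 4 is estimated at 1800 nM, with an expected range from 600 nM to 5500 nM.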

Compound 4, half-maximal effective concentration: 10000 nM
Estimate against measurement, compound 4: 5.6-fold (0.74 log units) below; measured number outside the range, above it.
By their numbers in this assay, from the lowest: compound 1; then compounds 2 and 4 (each within the scatter of the next). At a limit, above all of these: compound 3.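

In this assay, the exchange of 3,4-difluorophenyl for 2,3-difluorophenyl on a saturated chain carbon bound to an amine nitrogen in a ring gives an 8.1-fold higher number from compound 1 to compound 4 (0.91 log units; beyond the scatter) with no atom gained or lost. For the compounds shown here, compound 1 and compound 4 have the same atoms, joined differently, so the arrangement of the two fluorines on the phenyl group alone separates them, and this is the first reading at this position, since the earlier compounds all carry 3,4-difluorobenzyl. Nothing measured here bears on the reason for this difference.

As far as these compounds go, it remains open how an unsubstituted phenyl, a chlorophenyl or a methoxyphenyl would read at this position. From the compounds shown here alone, it is also open whether 2,3-difluorobenzyl has a similar effect on the cores of compound 2 and compound 3.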